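Trifluoromethyl in place of iodo

The source may report more compounds than this note shows. Statements on the series, on what has been measured and on what is new or still open speak of the compounds shown alone.

In an ADME assay on L6 cells (Rattus norvegicus) for cytotoxicity, read by resazurin assay, with a stated time of 72 h (on this read-out higher numbers stand for weaker inhibition and lower numbers for stronger inhibition), compound 2 (`O=C1[C@H]2N=NN(Cc3nc(-c4ccc(I)cc4)no3)[C@H]2C(=O)N1c1ccccc1`) gives 48.6 ug/mL and compound 1 (`O=C1[C@H]2N=NN(Cc3nc(-c4ccc(Br)cc4)no3)[C@H]2C(=O)N1c1ccccc1`) gives 58.6 ug/mL as its value, so the two stand within the scatter of each other. Compound 3 (`O=C1[C@H]2N=NN(Cc3nc(-c4ccc(C(F)(F)F)cc4)no3)[C@H]2C(=O)N1c1ccccc1`) carries trifluoromethyl in place of iodo on an aromatic carbon. Among the measured compounds shown here, the one measured step that bears on this is iodo in place of bromo, a 1.2-fold lower number from compound 1 to compound 2 (0.08 log units; within the scatter) in size, and it gives no sign of a real shift. The estimated change, a 1.1-fold higher number from compound 2 to compound 3 (0.03 log units; within the scatter) in size, is expected to stay within the scatter. For compound 3 the expected value is 52 ug/mL as a middle figure, with an estimated range from 28 ug/mL to 95 ug/mL overall.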

Compound 3, half-maximal inhibitory concentration: 44.4 ug/mL
Beside the measured number, compound 3's estimate is 1.2-fold (0.07 log units) above it; measured number inside the range.
By their numbers in this assay, from the lowest: compounds 3, 2 and 1 (each within the scatter of the next).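

In this assay, trifluoromethyl on this aromatic carbon gives a 1.1-fold lower number from compound 2 to compound 3 (0.04 log units; within the scatter) and a 1.3-fold lower number from compound 1 to compound 3 (0.12 log units; within the scatter), so a group that is not a single halogen atom, with four heavy atoms in place of the one of iodo, also causes no real shift. All three compounds now stand within the scatter of one another. No evidence at hand accounts for this flat reading.

As far as these compounds go, whether an amine or a carboxylic acid on this carbon would stay within the scatter remains open.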